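The source may hold more compounds than are shown below. What is called first, only, known or untested is meant among the compounds shown, and "the series" means these compounds.

In a functional assay on SGC-7901 cells (Homo sapiens) for cytotoxicity, read by MTT assay, with a stated time of 72 h (a lower number here means a stronger inhibitor, a higher number a weaker inhibitor), compound 1 `Oc1ccc(C2C/C(=N\NC(=S)N3CCOCC3)c3ccc(O)cc3O2)cc1` gives 52200 nM as its reading, compound 2 `CC(C)(C)NC(=S)N/N=C1\CC(c2ccc(O)cc2)Oc2cc(O)ccc21` gives 31000 nM and compound 3 `Oc1ccc(C2C/C(=N\NC(=S)N3CCCC3)c3ccc(O)cc3O2)cc1` gives 37000 nM on the same scale. The three share one core and differ only in the group on a thiocarbonyl carbon. Compound 3 lies within the scatter of both other compounds, so no order can be read among them. Compound 4 `CCCCNC(=S)N/N=C1\CC(c2ccc(O)cc2)Oc2cc(O)ccc21` carries butylamino in place of pyrrolidin-1-yl on a thiocarbonyl carbon and so has no ring there, like the (tert-butyl)amino of compound 2. The nearest guide is a 1.2-fold higher number from compound 2 to compound 3 (0.08 log units; within the scatter) for pyrrolidin-1-yl in place of (tert-butyl)amino, while a 1.7-fold lower number from compound 1 to compound 2 (0.23 log units; within the scatter) and a 1.4-fold lower number from compound 1 to compound 3 (0.15 log units; within the scatter) are the other two steps at this place. With all three steps this small, no step beyond the scatter is expected in this assay for compound 4. The estimated step is a 1.1-fold lower number from compound 3 to compound 4 (0.05 log units; within the scatter) and lies inside that scatter. Compound 4 is estimated at 33000 nM and the range from 15000 nM to 70000 nM is expected to hold most repeat measurements.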

Compound 4, half-maximal inhibitory concentration: 50800 nM
The estimate for compound 4 lay 1.5-fold (0.19 log units) below the measured number, within the range that was stated.
By their numbers in this assay, from the lowest: compounds 2, 3, 4 and 1 (each within the scatter of the next).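

Taking away the ring on this thiocarbonyl carbon and putting an open butylamino chain in its place, which also brings one hydrogen-bond donor, leaves no readable difference in this assay (a 1.4-fold higher number from compound 3 to compound 4 (0.14 log units; within the scatter)). The shape of the chain gives no readable difference either, with butyl in place of tert-butyl on an amide-type nitrogen (a 1.6-fold higher number from compound 2 to compound 4 (0.21 log units; within the scatter)), and the same holds for butylamino in place of morpholin-4-yl (a 1.0-fold lower number from compound 1 to compound 4 (0.01 log units; within the scatter)). All four groups at this position, with a ring or without one, thus lie within the scatter of each other in this assay, and no measurement shown here accounts for this. As far as these compounds go, whether a phenylamino group or a longer chain such as octylamino at this place would give a step beyond the scatter remains open.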